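The compounds below may be only part of what the source reports. "The series", "measured", "known", "first", "only" and "open" are said of these compounds alone.

Among the compounds with values here, compound 1 `COc1ccc(C2(c3cc(C(C)(C)C)ccc3O)C(=O)Nc3ccccc32)cc1` is the only member of this small set with a numerical result: in a functional assay on cells (Mus musculus) for antiproliferative activity, read by sulforhodamine B assay, with a stated time of 5 days (a lower number here means a stronger inhibitor, a higher number a weaker inhibitor), compound 1 gives 15700 nM. Compound 2 `COC(=O)c1cccc2c1NC(=O)C2(c1ccc(OC)cc1)c1cc(C(C)(C)C)ccc1O` reaches only the limit of the assay, reported in this assay as > 20000 nM. Within the data shown here, the one measured step, an at least 1.2-fold higher number from compound 1 to compound 2 (0.10 log units; that floor lies within the scatter), puts methoxycarbonyl in place of hydrogen on an aromatic carbon; it rests on that limit, (the limit of > 20000 nM in this assay, at which 1 of the 2 values shown sits), so its true size is unknown.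

Compound 3 `CC(C)(C)c1ccc(O)c(C2(c3ccc(O)cc3)C(=O)Nc3ccccc32)c1` differs from compound 1 by hydrogen in place of methyl on an oxygen on an aromatic ring. Among the measured compounds shown here, no measured step touches that position, and the single step that exists is a floor lying within the scatter, so nothing here argues for a shift in this assay in either direction beyond the scatter. Compound 3 is therefore expected to sit close to compound 1, a step of a 1.0-fold lower number from compound 1 to compound 3 (0.02 log units; within the scatter), with an estimate of 15000 nM and a likely range from 6000 nM to 40000 nM.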

Compound 3, half-maximal inhibitory concentration: 17300 nM
For compound 3 the middle estimate is 1.2-fold (0.06 log units) below the measured one; the measured number falls inside the stated range.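

Replacing methoxy with hydroxy on the aromatic ring, which turns 4-methoxyphenyl into 4-hydroxyphenyl, gives a 1.1-fold higher number from compound 1 to compound 3 (0.04 log units; within the scatter) in this assay. Within the data shown here, this is the first measured change at this position, and it shows that the methyl on this oxygen can give way to hydrogen with no difference that this assay can separate from the scatter. Nothing measured here offers an explanation for this result.

The compounds shown leave open what an amine, a carboxylic acid or a longer chain such as ethoxy would do in the same place, since only methoxy and hydroxy can be compared there. They also leave open whether any change to the core of compound 1 could give a clearly lower number.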